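The source may hold more compounds than are shown below. What is called first, only, known or untested is meant among the compounds shown, and "the series" means these compounds.

Measured compounds:
compound 1, `O=C(COc1ccc2c(=O)cc(-c3ccccc3)oc2c1)Nc1ccc2ccccc2c1`: > 10000 nM
compound 2, `O=C(COc1ccc2c(=O)c(-c3ccccc3)coc2c1)Nc1ccc2ccccc2c1`: 1370 nM

Two compounds share a core and an amide linked to a naphthalen-2-yl group; they differ only in where the phenyl sits on the core. In a functional assay on NPC-TW01 cells (Homo sapiens) for antiproliferative activity, read by MTT assay, with a stated time of 72 h (a higher number here means a weaker inhibitor of growth, a lower number a stronger inhibitor of growth), compound 1 gives > 10000 nM, which is a limit of the assay and not a number. Within the data shown here, compound 2 gives 1370 nM, the only true number obtained, so compound 2 stands as the one compound with a measurable value here, the other sitting at the limit of > 10000 nM in this assay, at which 1 of the 2 values shown sits.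

Compound 3, `COc1ccc(NC(=O)COc2ccc3c(=O)c(-c4ccccc4)coc3c2)cc1`, is not yet measured. It differs from compound 2 by 4-methoxyphenyl in place of naphthalen-2-yl on an amide-type nitrogen. Among the measured compounds shown here, no pair of measured compounds shows this change, so there is no measured step to lean on. A change of this size on the amide nitrogen is expected to move the value only modestly in this assay, most likely toward a somewhat higher number, with a real chance that the difference stays within the scatter.

For compound 3 the expected value is 2500 nM, between 800 nM and 8000 nM, a step estimated as a 1.8-fold higher number from compound 2 to compound 3 (0.26 log units; within the scatter).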

Compound 3, concentration for 50% growth inhibition: 6700 nM
Beside the measured number, compound 3's estimate is 2.7-fold (0.43 log units) below it; the range from low to high includes it.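

In this assay, replacing naphthalen-2-yl with 4-methoxyphenyl on the amide-type nitrogen gives a 4.9-fold higher number from compound 2 to compound 3 (0.69 log units; beyond the scatter), so the group at this position clearly influences growth inhibition, whereas the earlier pair differed only in where the phenyl sits on the shared core. This single change has several parts: two six-membered aromatic rings of carbon only leave, while one such ring enters with a methoxy group that adds an oxygen and a hydrogen-bond acceptor, and one step cannot separate these parts. Compound 1 remains the only compound whose result is a limit and not a number: the limit of > 10000 nM in this assay, at which 1 of the 3 values shown sits.

The compounds shown leave open which part of the change matters, and a plain phenyl on the same nitrogen, or a phenyl carrying an amine or a carboxylic acid, would help to tell these parts apart. They also leave open whether this change would act in the same way with the phenyl placed as in compound 1, whose result gives no true number to start from.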